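Notes on the amide cap: from compound 3 to compound 4

The compounds below may be only part of what the source reports. "The series", "measured", "known", "first", "only" and "open" are said of these compounds alone.

Measured so far in this series:
Compound 1, `CN(C)c1ccc(C(=O)Nc2cccc(NC(=O)COc3ccc4c(c3)CCC(=O)N4)c2)cc1`. In an assay on isolated protein for inhibition of Rho-associated protein kinase 1 (Homo sapiens), read by scintillation counting, radiometric assay and 33P incorporation, with a stated time of 40 min, in the presence of a further agent that is not named here (a higher number here means a weaker inhibitor, a lower number a stronger inhibitor), compound 1 gives > 10000 nM, which is a limit of the assay and not a number.
Compound 2, `CCCC(=O)Nc1cccc(NC(=O)COc2ccc3c(=O)ccoc3c2)c1`. Compound 2 gives 1430 nM.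
Compound 3, `CCc1ccc(C(=O)Nc2cccc(NC(=O)COc3ccc4c(=O)ccoc4c3)c2)cc1`. Compound 3 gives 235 nM.

For the measured compounds named here, compound 3 stands at the lowest of the two numbers; its nearest neighbour is compound 2, and a 6.1-fold lower number from compound 2 to compound 3 (0.78 log units; beyond the scatter) is the only single-point step available. Going by the values given here, compound 1 sits at the limit of > 10000 nM in this assay, at which 1 of the 3 values shown sits, and differs from compound 3 in more than one place, so no step is read from it.

Compound 4, `O=C(COc1ccc2c(=O)ccoc2c1)Nc1cccc(NC(=O)c2ccc(F)cc2)c1`, is not yet measured. It differs from compound 3 by fluoro in place of ethyl on an aromatic carbon, para to a large group. The step from compound 2 to compound 3 shows that the group on the amide carbonyl moves this assay by a modest amount when an aromatic ring replaces a chain. The present change keeps the aromatic ring and alters only what sits on it, so the expected step is smaller than that one: a slight weakening, at the edge of the scatter, is expected, a 1.7-fold higher number from compound 3 to compound 4 (0.23 log units; within the scatter). Compound 4 is therefore estimated at 400 nM, with a range from 150 nM to 1200 nM.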

Compound 4, half-maximal inhibitory concentration: 129 nM
Compound 4: middle estimate off by 3.1-fold (0.49 log units), on the high side; the measured number lies below the stated range.
By their numbers in this assay, from the lowest: compounds 4 and 3 (each within the scatter of the next); then compound 2. At a limit, above all of these: compound 1.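

In this assay, for the compounds shown here, the change at this position is the first one made on the aromatic ring itself, and a 1.8-fold lower number from compound 3 to compound 4 (0.26 log units; within the scatter) shows that fluoro and ethyl on this aromatic carbon are not told apart, so the smaller group with a single heavy atom serves as well as the two-carbon one. The gain over the propyl amide is now seen with a second aromatic cap: a 6.1-fold lower number from compound 2 to compound 3 (0.78 log units; beyond the scatter) is joined by an 11-fold lower number from compound 2 to compound 4 (1.04 log units; beyond the scatter), and both compound 3 and compound 4 hold it, with neither going against it among the compounds that differ in one place. Nothing measured here bears on the reason for these steps.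

Still open, as far as these compounds go, is how far this position tolerates other groups on the same aromatic carbon, such as a carboxylic acid or a longer chain like butyl, since only ethyl and fluoro are compared there. Compound 1 gives > 10000 nM, which is a limit of the assay and not a number, and as it differs from the others in more than one place, its steps cannot be read.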